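This account rests on a few compounds, and the source may have more. Where it says the series, first, only, none or still open, it means among the compounds named here.

In an ADME assay on L6 cells (Rattus norvegicus) for cytotoxicity (on this read-out lower numbers stand for stronger inhibition and higher numbers for weaker inhibition), compound 1 `CN1CCN(CCCN2CCC3(N(C)C)CC(c4ccccc4)C2C(c2ccccc2)C3)CC1` gives 54500 nM, and compound 3 `CN1CCN(CCN2CCC3(N(C)C)CC(c4ccccc4)C2C(c2ccccc2)C3)CC1` gives 70300 nM. The change between them, (4-methylpiperazin-1-yl in place of (4-methylpiperazin-1-yl)methyl on a saturated chain carbon, two bonds along the chain from an amine nitrogen in a ring), made a 1.3-fold higher number from compound 1 to compound 3 (0.11 log units; within the scatter). Compound 2 `CN1CCN(CCC(=O)NC2CC3(N4CCN(C)CC4)CC(c4ccccc4)C2C(c2ccccc2)C3)CC1` has a core that differs from that of compound 1 in a way not broken down here; in this assay compound 2 gives 67900 nM. Compound 4 `CN1CCN(CC(=O)NC2CC3(N4CCN(C)CC4)CC(c4ccccc4)C2C(c2ccccc2)C3)CC1` carries the same kind of change relative to compound 2, (4-methylpiperazin-1-yl in place of (4-methylpiperazin-1-yl)methyl on a saturated chain carbon bound to a carbonyl carbon). The surroundings differ: in the earlier pair the place is a saturated chain carbon two bonds along the chain from an amine nitrogen in a ring, whereas here it is a saturated chain carbon bound to a carbonyl carbon. Because a 1.3-fold higher number from compound 1 to compound 3 (0.11 log units; within the scatter) stayed within the scatter, the expected step is a 1.1-fold higher number from compound 2 to compound 4 (0.03 log units; within the scatter). Compound 4 is therefore estimated at 72000 nM, between 36000 nM and 144000 nM.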

Compound 4, half-maximal inhibitory concentration: 42100 nM
Compound 4: the middle estimate sits 1.7-fold (0.23 log units) above what was measured, within the range that was stated.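

In this assay, setting 4-methylpiperazin-1-yl in place of (4-methylpiperazin-1-yl)methyl on a saturated chain carbon bound to a carbonyl carbon gave a 1.6-fold lower number from compound 2 to compound 4 (0.21 log units; within the scatter). Set beside the earlier step, the change does not behave measurably differently on the two cores: the same change on two cores in this assay, a 1.3-fold higher number (0.11 log units; within the scatter) from compound 1 to compound 3 and a 1.6-fold lower number (0.21 log units; within the scatter) from compound 2 to compound 4, 2.1-fold (0.32 log units) apart, within the scatter of two such steps Within this series, then, the change can be carried between these two cores without a step that stands out from the scatter, but two pairs in one assay cannot show that it would behave the same way on any other core.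

On these data alone, it remains open whether a longer chain would give a step beyond the scatter. The same applies to a morpholine or a carboxylic acid in place of the 4-methylpiperazin-1-yl group.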